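This account rests on a few compounds, and the source may have more. Where it says the series, first, only, none or still open, it means among the compounds named here.

Measured compounds, with their numbers in an assay on microsomes from brain for inhibition of Fatty-acid amide hydrolase 1 (Rattus norvegicus), read by fluorescence and HPLC, with a stated time of 45 min; on this read-out lower numbers stand for stronger inhibition and higher numbers for weaker inhibition:

compound 1, `O=C(COc1ccc(Oc2ccccc2)cc1)Cn1ncc2cc(C(=O)O)ccc21`: 55 nM
compound 2, `O=C(COc1ccc(Oc2ccccc2)cc1)Cn1ncc2ccccc21`: 2600 nM
compound 3, `O=C(COc1ccc(Oc2ccccc2)cc1)Cn1ncc2cc(NC(=O)Oc3ccccc3)ccc21`: 2100 nM

Compound 3 stands second highest of the three, next to compound 2 and far from compound 1. The step of a 1.2-fold lower number from compound 2 to compound 3 (0.09 log units; within the scatter) lies within the scatter, so compound 2 and compound 3 are not separated on this read-out. The step of a 38-fold higher number from compound 1 to compound 3 (1.58 log units; beyond the scatter) is large, as is a 47-fold higher number from compound 1 to compound 2 (1.67 log units; beyond the scatter); on these numbers only carboxy at that aromatic carbon gives a low number, and a hydrogen or a (phenoxycarbonyl)amino group there behaves alike.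

Compound 4, `CCNC(=O)Nc1ccc2c(cnn2CC(=O)COc2ccc(Oc3ccccc3)cc2)c1`, differs from compound 3 by ethylamino in place of phenoxy on a carbonyl carbon. Going by the values given here, no measured step touches this part of the molecule: every measured step changes the group on the aromatic carbon, none changes what sits on the carbonyl carbon of that group. Among the compounds with values here, the only guide is that compound 3 and compound 2 give the same number, so a further change within the (phenoxycarbonyl)amino group has no measured precedent for moving the number in either direction. The expectation is therefore no step beyond the scatter. Compound 4 is expected to give 2000 nM, with a range from 600 nM to 6000 nM. The estimated step is a 1.1-fold lower number from compound 3 to compound 4 (0.02 log units; within the scatter).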

Compound 4, half-maximal inhibitory concentration: 1600 nM
Compound 4: the middle estimate sits 1.3-fold (0.10 log units) above what was measured, within the range that was stated.
By their numbers in this assay, from the lowest: compound 1; then compounds 4, 3 and 2 (each within the scatter of the next).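

In this assay, ethylamino in place of phenoxy on a carbonyl carbon (a 1.3-fold lower number from compound 3 to compound 4 (0.12 log units; within the scatter)) does not separate the two compounds, even though this change removes a six-membered aromatic ring and adds a hydrogen-bond donor. Going by these compounds alone, this is the first step that alters the inside of the group on the aromatic carbon rather than replacing it, and on this pair that part of the group tolerates a large change in what sits on the carbonyl carbon. The (ethylcarbamoyl)amino group also stays level with hydrogen (a 1.6-fold lower number from compound 2 to compound 4 (0.21 log units; within the scatter)) and remains far from carboxy (a 29-fold higher number from compound 1 to compound 4 (1.46 log units; beyond the scatter)), so among the four compounds carboxy alone stands apart from hydrogen and both substituted amino groups, and no supporting measurement accounts for that separation.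

From the compounds shown here alone, it remains open whether any other group at this aromatic carbon, such as a methyl ester, a primary amide or a carboxylic acid on a longer chain, comes close to carboxy. Going by these compounds, it is also open whether a carboxylic acid or an amine at the end of the chain on the carbonyl carbon would move the number out of the range shared by compounds 2, 3 and 4.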